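Removing the Methoxy Group from a Urotensin-2 Agonist

The source may hold more compounds than are shown below. What is called first, only, known or untested is meant among the compounds shown, and "the series" means these compounds.

Compound 1 `COc1ccc(CCC(=O)NC(CCN(C)C)c2ccc3ccccc3c2)cc1` and compound 2 `Cc1ccc(C(CCN(C)C)NC(=O)/C=C/c2ccc(C(F)(F)F)cc2)cc1` have been tested in a functional assay on NIH3T3 cells for agonist activity at Urotensin-2 receptor (Homo sapiens), with a stated time of 5 days; on this read-out higher numbers stand for larger maximal responses and lower numbers for smaller maximal responses. In this assay compound 1 gives 113%, the highest of the two numbers, while compound 2 gives 96%, a gap beyond the usual scatter. Compound 3 `CN(C)CCC(NC(=O)CCc1ccccc1)c1ccc2ccccc2c1` has not yet been measured in this assay. It differs from compound 1 in one place: hydrogen in place of methoxy on an aromatic carbon. Among the compounds with values here, no measured pair shows this change, so its effect is unknown. The estimated step of a number 8 percentage points lower from compound 1 to compound 3 (within the scatter) is expected to remain within the scatter. For compound 3 the expected value is 105%, with a range from 85% to 125%.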

Compound 3, largest response reached (reported as efficacy), in percent of the reference or control that the assay uses: 107%
The estimate for compound 3 lay 2 percentage points below the measured number, within the range that was stated.
By their numbers in this assay, from the lowest: compound 2; then compounds 3 and 1 (each within the scatter of the next).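

In this assay, replacing the methoxy of the 4-methoxyphenyl group with hydrogen gives a number 6 percentage points lower from compound 1 to compound 3 (within the scatter), so at this place, para to a large group, the response holds with plain phenyl and the methoxy is not required for it. Within the data shown here, this is the first reading of any change at this position. Nothing measured on these compounds accounts for the result. The compounds shown leave open how an amine, a carboxylic acid or a fluorine atom at this same place would act, and whether hydrogen in place of methoxy reads the same on a different core.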